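This account rests on a few compounds, and the source may have more. Where it says the series, first, only, none or still open, it means among the compounds named here.

Compound 1 `COc1ccccc1/C=C/C(=O)/C=C/c1ccc(OCc2cn(CCCOc3cc(=O)oc4ccccc34)nn2)c(OC)c1` is the stronger of two measured compounds in a functional assay on HCT-116 cells (Homo sapiens) for inhibition, read by sulforhodamine B assay, with a stated time of 48 h, tested at 50 uM; a lower number here means less inhibition of growth, a higher number more inhibition of growth at the concentration tested. In this assay compound 1 gives 53%. Compound 2 `COc1cc(/C=C/C(=O)/C=C/c2ccco2)ccc1OCc1cn(CCCCCOc2cc(=O)oc3ccccc23)nn1` sits well below it, beyond the usual scatter: in this assay compound 2 gives 37%. Compound 3 `COc1cc(/C=C/C(=O)/C=C/c2ccco2)ccc1OCc1cn(CCCOc2cc(=O)oc3ccccc23)nn1` has not been measured; it differs from compound 1 in one place: furan-2-yl in place of 2-methoxyphenyl on a double-bonded chain carbon bound to a double-bonded chain carbon. Among the compounds with values here, no measured pair shows this change alone, so the expected step of a number 11 percentage points lower from compound 1 to compound 3 (beyond the scatter) is a modest drop, leaning on the lower result of compound 2 at 37%. Compound 3 is therefore estimated at 42%, within the range 28% to 56%.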

Compound 3, percent growth inhibition at one concentration: 51%
The estimate for compound 3 lay 9 percentage points below the measured number; measured number inside the range.
By their numbers in this assay, from the lowest: compound 2; then compounds 3 and 1 (each within the scatter of the next).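

In this assay the change from 2-methoxyphenyl to furan-2-yl on this chain gives a number 2 percentage points lower from compound 1 to compound 3 (within the scatter). At this position, then, a five-membered aromatic ring with fewer heavy atoms cannot be told apart from the six-membered one carrying a methoxy group. No data at hand explain this result.

On these data alone, whether the position accepts a very different group, such as a phenyl ring bearing a carboxylic acid or an amine, remains open. Also open, as far as these compounds go, is whether the same swap gives a similar result with a longer chain at the other end of the molecule.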